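This account rests on a few compounds, and the source may have more. Where it says the series, first, only, none or still open, it means among the compounds named here.

Three compounds share the core of compound 2 `CC(C(=O)NCc1ccc(C(F)(F)F)nc1NCc1ccccc1)c1ccc(NS(C)(=O)=O)c(F)c1` and have been measured in a functional assay on CHO-K1 cells for antagonist activity at transient receptor potential cation channel subfamily V member 1 (Homo sapiens), read by FLIPR; a higher number here means a weaker inhibitor, a lower number a stronger inhibitor. Compound 2 gives 203 nM, the lowest of the three numbers. Compound 3 `CC(C(=O)NCc1ccc(C(F)(F)F)nc1NCc1ccc(Cl)cc1)c1ccc(NS(C)(=O)=O)c(F)c1`, which carries chloro in place of hydrogen on an aromatic carbon, gives 414 nM; the step of a 2.0-fold higher number from compound 2 to compound 3 (0.31 log units; beyond the scatter) is modest but beyond the scatter. Compound 1 `CC(C(=O)NCc1ccc(C(F)(F)F)nc1NCC1CCN(C(=O)OC(C)(C)C)CC1)c1ccc(NS(C)(=O)=O)c(F)c1` gives 1140 nM, the furthest of the three from compound 2.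

Compound 4 `CC(C(=O)NCc1ccc(C(F)(F)F)nc1N1CCCC1)c1ccc(NS(C)(=O)=O)c(F)c1` differs from compound 2 by pyrrolidin-1-yl in place of benzylamino on an aromatic carbon. For the measured compounds named here, no measured step covers this kind of exchange: the step from compound 2 to compound 3 alters only a substituent on the group that here leaves, and the values of compound 1 and compound 2 show only that a different non-aromatic replacement of the benzylamino group went with a higher number. Because compound 1 gives 1140 nM and compound 3 gives 414 nM, the expectation for compound 4 is a somewhat higher number than compound 2, with wide uncertainty. Compound 4 is therefore estimated at 500 nM, in the range 150 nM to 2000 nM, an expected step of a 2.5-fold higher number from compound 2 to compound 4 (0.39 log units; beyond the scatter).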

Compound 4, half-maximal inhibitory concentration: 211 nM
Beside the measured number, compound 4's estimate is 2.4-fold (0.37 log units) above it, and the stated range covers the measured number.
By their numbers in this assay, from the lowest: compounds 2, 4 and 3 (each within the scatter of the next, the first and the last beyond it); then compound 1.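

In this assay, pyrrolidin-1-yl can take the place of benzylamino on this aromatic carbon next to the ring nitrogen with a 1.0-fold higher number from compound 2 to compound 4 (0.02 log units; within the scatter) as the result. In this pair, therefore, the number holds without the six-membered aromatic ring of carbon only and without the hydrogen-bond donor of the leaving group. The comparison with the chlorinated group gives a 2.0-fold lower number from compound 3 to compound 4 (0.29 log units; within the scatter) and so also stays within the scatter, and no measurement available here explains why these groups give such similar numbers.

The compounds shown leave open whether morpholin-4-yl, dimethylamino or a plain amino group would give a number like that of compound 4. They also leave open whether a hydroxyl or a fluoro group on the pyrrolidin-1-yl ring would change it.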